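Ethynyl in place of phenyl on the shared core

The source may hold more compounds than are shown below. What is called first, only, known or untested is meant among the compounds shown, and "the series" means these compounds.

Measured in a functional assay on K562 cells (Homo sapiens), read by MTT assay, with a stated time of 72 h; on this read-out lower numbers stand for stronger inhibition and higher numbers for weaker inhibition:
- compound 1 `C#Cc1cn([C@@H]2O[C@H](CO)[C@@H](O)[C@H]2O)c2ncnc(OC)c12`: 300 nM
- compound 2 `CSc1ncnc2c1c(-c1ccccc1)cn2[C@@H]1O[C@H](CO)[C@@H](O)[C@H]1O`: > 20000 nM (a limit of the assay, not a number)

Compound 2 stands at a limit, not at a number: the limit of > 20000 nM in this assay, at which 1 of the 2 values shown sits.

Compound 3 `C#Cc1cn([C@@H]2O[C@H](CO)[C@@H](O)[C@H]2O)c2ncnc(SC)c12` is still to be measured in this assay. Relative to compound 2, it has ethynyl in place of phenyl on an aromatic carbon of the five-membered aromatic ring: ethynyl in place of phenyl on an aromatic carbon. Within the data shown here, no measured pair isolates this change, so the expectation rests on a single comparison. Compound 1 carries ethynyl at the same place and gives 300 nM. A large step towards stronger inhibition, well beyond the scatter, is therefore expected. The expected step is an at least 66-fold lower number from compound 2 to compound 3 (1.82 log units; beyond the scatter). Going by these compounds, because compound 2 offers only a limit, the true size of this step remains open, and a result at the limit cannot be ruled out. Compound 3 is estimated at 300 nM, with an expected range of 60 nM to 2000 nM.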

Compound 3, half-maximal inhibitory concentration: 30 nM
For compound 3 the middle estimate is 10-fold (1.00 log units) above the measured one; measured number below the stated range.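

In this assay, the exchange of phenyl for ethynyl on an aromatic carbon of the five-membered aromatic ring now has a direct pair, one in which nothing else on the shared core differs (an at least 660-fold lower number from compound 2 to compound 3 (2.82 log units; beyond the scatter)). Compound 2 stands at a limit of the assay and not at a number, which leaves the true size of this step open: the limit of > 20000 nM in this assay, at which 1 of the 3 values shown sits. With ethynyl held constant, the group exchanged in the other place also proves to matter, a modest step beyond the scatter for methylsulfanyl in place of methoxy on an aromatic carbon (a 10-fold lower number from compound 1 to compound 3 (1.00 log units; beyond the scatter)), something the earlier pair could not show, as compound 1 and compound 2 differ in two places.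

The compounds shown leave open whether ethynyl itself is required on this carbon, or whether a nitrile, a bromine atom or a longer alkyne chain would serve there as well. They also leave open how far the gain from methylsulfanyl extends, since an ethylsulfanyl group or an amine in its place would show whether this exchange is part of a wider trend.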